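Swapping a phenoxy for dimethylamino on a pyrazole series

The source may report more compounds than this note shows. Statements on the series, on what has been measured and on what is new or still open speak of the compounds shown alone.

Compound 1 `COc1cc(C)cc(-c2c(-c3ccnc(-c4ccc(C(C)=O)cc4)c3)cnn2CC#N)c1` in a functional assay on KM12 cells (Homo sapiens) for inhibition, read by sulforhodamine B assay, with a stated time of 48 h (on this read-out lower numbers stand for stronger inhibition of growth and higher numbers for weaker inhibition of growth), gives > 100000 nM, a limit of the assay rather than a number. Compound 2 `COc1cc(C)cc(-c2nn(CC#N)cc2-c2ccc(-c3cccc(C(C)=O)c3)nc2)c1` gives 13900 nM. Compound 3 `Cc1cc(O)cc(-c2nn(CC#N)cc2-c2ccnc(-c3ccc(Oc4ccccc4)cc3)c2)c1` gives 4870 nM.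

Compound 3 thus has the lowest of the two numbers shown; compound 2 stands beyond the scatter from it, and compound 1 contributes only a limit. Compound 4 `Cc1cc(O)cc(-c2nn(CC#N)cc2-c2ccnc(-c3ccc(N(C)C)cc3)c2)c1` differs from compound 3 in one place: dimethylamino in place of phenoxy on an aromatic carbon, a dimethylamino in place of phenoxy on an aromatic carbon. Among the measured compounds shown here, no measured pair shows this change, so the expected step is taken as small, within or just beyond the scatter, with no firm direction. For compound 4 the estimated value is 8000 nM, within 2000 nM to 40000 nM, an expected step of a 1.6-fold higher number from compound 3 to compound 4 (0.22 log units; within the scatter).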

Compound 4, concentration for total growth inhibition: 7660 nM
Compound 4: the middle estimate sits 1.0-fold (0.02 log units) above what was measured, and the stated range covers the measured number.
By their numbers in this assay, from the lowest: compounds 3, 4 and 2 (each within the scatter of the next, the first and the last beyond it). At a limit, above all of these: compound 1.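

Replacing phenoxy with dimethylamino on an aromatic carbon, para to a large group, gives a 1.6-fold higher number from compound 3 to compound 4 (0.20 log units; within the scatter) in this assay. A group of 7 heavy atoms with a ring and one of 3 heavy atoms with no ring thus leave the number within the scatter, so at this place the ring is not required for growth inhibition at this level. Nothing shown here explains why the two groups read alike. Going by these compounds, what an amine, a methoxy or a carboxylic acid would give at this place stays open.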